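Swapping the aryl group on sulfur in a diamino core

The compounds below may be only part of what the source reports. "The series", "measured", "known", "first", "only" and "open" are said of these compounds alone.

Compound 2 `COc1ccc(Sc2nc3cc(N)cc(N)c3nc2-c2ccccc2)cc1` carries a (4-methoxyphenyl)sulfanyl group on its shared core. In a functional assay on MDA-MB-231 cells (Homo sapiens) for inhibition, read by sulforhodamine B assay, with a stated time of 48 h (a higher number here means a weaker inhibitor of growth, a lower number a stronger inhibitor of growth), compound 2 reaches only a limit of the assay, < 100000 nM, so no exact number is known for it. The related compound 1 `Nc1cc(N)c2nc(-c3ccccc3)c(Oc3ccc(Cl)c(Cl)c3)nc2c1` bears a 3,4-dichlorophenoxy group in the same position, and in this assay compound 1 gives 10200 nM. Among the measured compounds shown here, the one measured step, a step that the limit leaves unreadable from compound 1 to compound 2, cannot be read as a size, as the limit of < 100000 nM in this assay, at which 1 of the 2 values shown sits, shows.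

Compound 3 `Nc1cc(N)c2nc(-c3ccccc3)c(Sc3ccc(Cl)c(Cl)c3)nc2c1` has not been measured. It differs from compound 2 by 3,4-dichlorophenyl in place of 4-methoxyphenyl on a sulfur. This change therefore gives compound 3 the same 3,4-dichlorophenyl group that compound 1 carries, joined through sulfur instead of oxygen. With no readable step to lean on, the expectation for compound 3 is drawn mainly from compound 1 and its value of 10200 nM, with wide uncertainty. The step that the limit leaves unreadable from compound 2 to compound 3 is therefore only an estimate. Compound 3 is expected to give about 12000 nM in this assay, within a range from 3000 nM to 60000 nM.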

Compound 3, concentration for 50% growth inhibition: 16600 nM
Compound 3: middle estimate off by 1.4-fold (0.14 log units), on the low side, and the stated range covers the measured number.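

Among the compounds shown here, compound 3 gives the first readable comparison at this position. It keeps the 3,4-dichlorophenyl group of compound 1 and changes only the atom that joins this group to the shared core. The outcome is a 1.6-fold higher number from compound 1 to compound 3 (0.21 log units; within the scatter), so in this assay this pair does not separate a sulfur link from an oxygen link. Compound 2 remains a limit and not a number, so neither step involving it can be read, and the swap of 4-methoxyphenyl for 3,4-dichlorophenyl on a sulfur has no measurable size: the limit of < 100000 nM in this assay, at which 1 of the 3 values shown sits.

As far as these compounds go, this sulfur and oxygen comparison rests on a single pair carrying one aryl group, so it is open whether the same holds with other groups on the link, such as an unsubstituted phenyl or a phenyl bearing a carboxylic acid. Also open, from the compounds shown here alone, is how an amine link in place of sulfur or oxygen would read in this assay, or a longer chain placed on the sulfur in place of the aromatic ring.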